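Turning the cyclobutane lactam over: compound 3 expected

This account rests on a few compounds, and the source may have more. Where it says the series, first, only, none or still open, it means among the compounds named here.

Compound 1 `C[C@@H](OC[C@]1(c2ccccc2)C[C@@H](N2CCCC2=O)C1)c1cc(C(F)(F)F)cc(C(F)(F)F)c1` gives 0.4 nM in an assay on CHO cells for displacement of a labelled ligand from Substance-P receptor (Homo sapiens); a lower number here means a stronger inhibitor, a higher number a weaker inhibitor. Compound 2 `C[C@@H](OC[C@]1(c2ccccc2)C[C@](N)(C(=O)N2CCCCC2)C1)c1cc(C(F)(F)F)cc(C(F)(F)F)c1` gives 1.3 nM in this assay.

Compound 1 has the lowest number of the two; compound 2 stands higher, and that gap is beyond the scatter. Compound 3 `C[C@@H](OC[C@]1(c2ccccc2)C[C@H](N2CCCC2=O)C1)c1cc(C(F)(F)F)cc(C(F)(F)F)c1` keeps every atom of compound 1 and changes only configuration: the two compounds have the same atoms and bonds and differ only in configuration as drawn: 2 of 3 stereo elements differ; a stereocentre at a saturated ring carbon is drawn r in compound 1 and s in compound 3; a stereocentre at a saturated ring carbon is drawn R in compound 1 and S in compound 3. Among the measured compounds shown here, no measured pair here shows what such a change does, so the direction is uncertain, but flipping two ring centres usually costs binding. Compound 3 is therefore estimated at 5 nM (range 0.8 nM to 40 nM), a step of a 13-fold higher number from compound 1 to compound 3 (1.10 log units; beyond the scatter) towards weaker binding.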

Compound 3, inhibition constant: 0.3 nM
Compound 3: the middle estimate sits 17-fold (1.22 log units) above what was measured; measured number outside the range, below it.
By their numbers in this assay, from the lowest: compounds 3 and 1 (each within the scatter of the next); then compound 2.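

Reversing the drawn configuration at the two saturated ring carbons gives a 1.3-fold lower number from compound 1 to compound 3 (0.12 log units; within the scatter) in this assay, so at this position the lactam is accepted in either arrangement. This is the first direct view of what configuration does on the shared core, and the pair can be read cleanly because nothing else separates the two compounds: the fact that compounds 1 and 3 differ only in the configuration as drawn

The compounds shown leave open whether this indifference to configuration would hold for another group at the same position, such as a carboxylic acid in place of the lactam.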